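Cyclopropyl in Place of Cyano on the Shared Core

The source may report more compounds than this note shows. Statements on the series, on what has been measured and on what is new or still open speak of the compounds shown alone.

Values in an ADME assay on microsomes from liver (Rattus norvegicus) for metabolic stability; a higher number here means faster removal of the compound, a lower number slower removal
compound 1 `CNc1nc(NC2(C#N)CCCCC2)nc(OC)n1` gives 196 mL/min/kg
compound 2 `CNc1nc(C#N)nc(NC2(C#N)CCCCC2)n1` gives 122 mL/min/kg

The value of compound 2 lies within the usual scatter of that of compound 1, so the two cannot be ranked. Still unmeasured is compound 3 `CNc1nc(NC2(C#N)CCCCC2)nc(C2CC2)n1`, which differs from compound 2 by cyclopropyl in place of cyano on an aromatic carbon. Within the data shown here, the one measured step at this carbon put cyano in place of methoxy and came to a 1.6-fold lower number from compound 1 to compound 2 (0.21 log units; within the scatter), so it offers only a rough guide to a different incoming group. No change beyond the scatter is therefore expected in this assay, with a slight lean toward a higher number. The estimate amounts to a 1.4-fold higher number from compound 2 to compound 3 (0.14 log units; within the scatter) as the expected step. For compound 3 the expected value is 170 mL/min/kg, with an estimated range from 90 mL/min/kg to 310 mL/min/kg for the measurement.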

Compound 3, clearance: 276 mL/min/kg
The estimate for compound 3 lay 1.6-fold (0.21 log units) below the measured number; the measured number falls inside the stated range.
By their numbers in this assay, from the lowest: compounds 2, 1 and 3 (each within the scatter of the next, the first and the last beyond it).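

In this assay, the swap on this aromatic carbon, between two ring nitrogen atoms, gave a 2.3-fold higher number from compound 2 to compound 3 (0.35 log units; beyond the scatter) and is the only step shown at this position that passes the scatter. The other step at this carbon, a 1.4-fold higher number from compound 1 to compound 3 (0.15 log units; within the scatter) and so no separation of the two, shows that cyclopropyl stands apart from cyano but not from methoxy, while cyano and methoxy also remain unranked. No evidence is available that would account for the step from cyano to cyclopropyl.

The compounds shown leave open how an amine or a chlorine atom on this carbon would compare with these three groups. They also leave open whether the step from cyano to cyclopropyl keeps its size when the methylamino group or the group of 9 heavy atoms is changed.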